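This account rests on a few compounds, and the source may have more. Where it says the series, first, only, none or still open, it means among the compounds named here.

Of the compounds shown here, two built on a shared core have been measured in an assay on membranes from HeLa cells for displacement of a labelled ligand from adenosine receptor A3 (Homo sapiens), read by scintillation counting, with a stated time of 180 min, tested at 1 uM; a lower number here means less inhibition, a higher number more inhibition at the concentration tested (going by the name of the read-out). Compound 1, `COC(=O)C1=C(C)NC(=O)NC1c1ccoc1`, gives 2% in this assay. Compound 2, `CC1=C(C(=O)SC(C)C)C(c2ccco2)NC(=O)N1`, gives 1% in this assay. On the numbers shown, compound 2 stands alongside compound 1: the two values lie within the usual scatter of each other, so neither can be separated from the other, and both sit close to zero at the concentration tested.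

Compound 3, `CC1=C(C(=O)SC(C)C)C(c2ccoc2)NC(=O)N1`, has not yet been measured. It differs from compound 2 in a single place: furan-3-yl in place of furan-2-yl on a saturated ring carbon. Going by the values given here, no pair of measured compounds that differ in one place is available, so the size of such a step in this assay cannot be read from the data. Both measured values lie near zero, which gives no ground for expecting a rise or a fall. The expected step is a number 1 percentage points higher from compound 2 to compound 3 (within the scatter), that is, none beyond the scatter. Compound 3 is accordingly estimated at 2%, with a range from -8% to 12%.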

Compound 3, a percentage reported as inhibition, at one concentration (the size of the read-out at that concentration, not a potency): 3%
Beside the measured number, compound 3's estimate is 1 percentage points below it, and the stated range covers the measured number.
By their numbers in this assay, from the lowest: compounds 2, 1 and 3 (each within the scatter of the next).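

Going by these compounds alone, compound 3 gives the first one-place readings in this assay. With furan-3-yl in place of furan-2-yl on the saturated ring carbon, the result is a number 2 percentage points higher from compound 2 to compound 3 (within the scatter), so on these numbers the two furan attachments cannot be told apart at this position while the isopropylsulfanyl carbonyl group stays in place. With isopropylsulfanyl in place of methoxy on the carbonyl carbon and furan-3-yl held fixed, the result is a number 1 percentage points higher from compound 1 to compound 3 (within the scatter), so the two groups on the carbonyl carbon cannot be told apart either, and nothing at hand offers an explanation for these readings.

Within the data shown here, all three compounds sit close to zero, so these steps show only that the groups compared cannot be separated at the concentration tested, not how they would compare in a compound with a clearly measurable read-out. On these data alone, whether a phenyl ring in place of the furan, or an amine or a longer chain in place of isopropylsulfanyl, would give a read-out clear of the scatter remains open.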